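A few compounds are considered here, and "the series" means these few. Any claim that something is new, unique, unknown or untested is made for them only; others in the source may bear on it.

Values in a functional assay, read by fluorescence and spectrophotometry, with a stated time of 1 h; on this read-out lower numbers stand for an effect already at smaller amounts and higher numbers for an effect only at larger amounts of compound:
compound 1 `O=S(=O)(/C=C/c1ccc(O)c(O)c1)CCC1CCCCC1`: 9800 nM
compound 2 `CCCCCCCCCCCS(=O)(=O)/C=C/c1ccc(O)c(O)c1`: 11400 nM

Among the measured compounds shown here, only two numbers exist so far in this assay. Compound 2 at 11400 nM stands level with compound 1 at 9800 nM, the two lying within the usual scatter of each other.

The next compound to be measured is compound 3 `CCCCCCCCCS(=O)(=O)/C=C/c1ccc(O)c(O)c1`. It differs from compound 2 by a single change: hydrogen in place of ethyl on a saturated chain carbon, nine bonds along the chain from a sulfonyl sulfur. In words, this is hydrogen in place of ethyl on a saturated chain carbon, nine bonds along the chain from a sulfonyl sulfur. The same difference, cut one bond further out, reads butyl to ethyl.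

For the measured compounds named here, no measured pair isolates a change of this kind, so there is no direct evidence for its size or direction. Going by the values given here, the only guide is that compound 1 at 9800 nM and compound 2 at 11400 nM do not separate beyond the scatter. No step beyond the scatter is therefore expected in this assay, and no direction is favoured. The estimated step is a 1.1-fold lower number from compound 2 to compound 3 (0.06 log units; within the scatter). For compound 3 the expected value is 10000 nM, with an estimated range of 4500 nM to 23000 nM.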

Compound 3, half-maximal effective concentration: 7700 nM
Beside the measured number, compound 3's estimate is 1.3-fold (0.11 log units) above it; low and high end bracket the measured number.
By their numbers in this assay, from the lowest: compounds 3, 1 and 2 (each within the scatter of the next).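

In this assay, among the compounds shown here, hydrogen in place of ethyl on a saturated chain carbon, nine bonds along the chain from a sulfonyl sulfur, gives a 1.5-fold lower number from compound 2 to compound 3 (0.17 log units; within the scatter) and so supplies the first measured pair at this position, a pair that does not separate the two chains. Heptyl in place of cyclohexyl on a saturated chain carbon, two bonds along the chain from a sulfonyl sulfur, gives a 1.3-fold lower number from compound 1 to compound 3 (0.10 log units; within the scatter) and so shows that in this assay the open chain of compound 3 and the cyclohexyl-bearing chain of compound 1 stand level. No supporting measurement is available to interpret either step.

The compounds shown leave open whether a longer chain than that of compound 2, or a shorter chain than that of compound 3, would give a step beyond the scatter in this assay. Also open, going by these compounds, is whether an amine or a carboxylic acid on the chain would do so, as all three compounds carry only carbon and hydrogen in this part of the structure.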